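The source may hold more compounds than are shown below. What is called first, only, known or untested is meant among the compounds shown, and "the series" means these compounds.

Cell-growth tests show whether a compound can stop cancer cells from multiplying, and here the read-out is a functional assay on SNU-423 cells (Homo sapiens) for inhibition, read by MTT assay, with a stated time of 72 h; on this read-out lower numbers stand for stronger inhibition and higher numbers for weaker inhibition. For compound 1 `Nc1ncnc2c1c(-c1cnc3[nH]ccc3c1)nn2CCCCCC(=O)NO` the entry is "not determined" (no result reported), so it offers no guide. Compound 2 `Nc1nc2cc(-c3nn(CCCCCCCCCC(=O)NO)c4ncnc(N)c34)ccc2o1` gives > 50000 nM, which is a limit of the assay and not a number. Compound 2 therefore has no exact position, and no measured number stands beside it for comparison. Compound 3 `Nc1ncnc2c1c(-c1cnc3[nH]ccc3c1)nn2CCCCCCCCCC(=O)NO` loses the 2-amino-1,3-benzoxazol-5-yl group of compound 2 and carries a slightly smaller two-ring group on the same aromatic carbon: a group of 9 heavy atoms (7 carbon, 2 nitrogen; one five-membered aromatic ring with 1 hetero atom, one six-membered aromatic ring with 1 hetero atom) in place of a group of 10 heavy atoms (7 carbon, 2 nitrogen, 1 oxygen; one five-membered aromatic ring with 2 hetero atoms, one six-membered aromatic ring of carbon only), on an aromatic carbon. Among the measured compounds shown here, no measured pair in this assay shows what such a swap does, so only a small move toward stronger inhibition is expected, with the estimated change being an at least 1.6-fold lower number from compound 2 to compound 3 (0.22 log units; that floor lies within the scatter). Compound 3 is estimated at 30000 nM, with an expected range of 8000 nM to 100000 nM.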

Compound 3, half-maximal inhibitory concentration: 8160 nM
Compound 3: middle estimate off by 3.7-fold (0.57 log units), on the high side; the range from low to high includes it.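

In this assay, the group on this aromatic carbon clearly matters: replacing the 2-amino-1,3-benzoxazol-5-yl group with the slightly smaller two-ring group gives an at least 6.1-fold lower number from compound 2 to compound 3 (0.78 log units; beyond the scatter) for this one change. Among the compounds shown here, compound 3 is also the first compound here with an exact number, so it gives any later change at this position a fixed point for comparison. The true size of the step remains unknown, because the value for compound 2 is only a limit of the assay, so the step gives only a minimum: the limit of > 50000 nM in this assay, at which 1 of the 3 values shown sits.

The compounds shown do not reveal which difference between the two groups accounts for the step, such as the amino group, the oxygen or the position of the ring nitrogens. From the compounds shown here alone, it also remains open how a simple phenyl ring or a quinoline at this carbon would compare with compound 3.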